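The source may report more compounds than this note shows. Statements on the series, on what has been measured and on what is new or still open speak of the compounds shown alone.

Three compounds of the series have numbers in a functional assay on HT-29 cells (Homo sapiens) for antiproliferative activity, read by sulforhodamine B assay, with a stated time of 72 h; on this read-out lower numbers stand for stronger inhibition and higher numbers for weaker inhibition. Compound 1 `Clc1ccc(C(/C=C/c2ccccc2)=N\Nc2nncc3ccccc23)cc1` gives 2.3 nM. Compound 2 `O=C1CS/C(=N/Nc2nncc3ccccc23)N1c1ccccc1` gives 47 nM, and compound 3 `O=S(=O)(Nc1ccccn1)c1ccc(Nc2nncc3ccccc23)cc1` gives 38 nM. Compound 3 thus holds the second highest of the three numbers; its value and that of compound 2 lie within the scatter of each other, whereas compound 1 sits beyond the scatter with a clearly lower number. Compound 4 `NS(=O)(=O)c1ccc(Nc2nncc3ccccc23)cc1` differs from compound 3 in one place.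

hydrogen in place of pyridin-2-yl on a sulfonamide nitrogen

For the measured compounds named here, no measured pair shows this change, so its size is open; a step toward a higher number in this assay is expected, possibly not beyond the scatter. Compound 4 is estimated at 80 nM, with a range from 25 nM to 250 nM. The expected step is a 2.1-fold higher number from compound 3 to compound 4 (0.32 log units; beyond the scatter).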

Compound 4, half-maximal inhibitory concentration: 12 nM
Compound 4: middle estimate off by 6.7-fold (0.82 log units), on the high side, outside the stated range (below it).
By their numbers in this assay, from the lowest: compound 1; then compound 4; then compounds 3 and 2 (each within the scatter of the next).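

At this position the pyridin-2-yl group is not required for activity in this assay: replacing it with hydrogen on the sulfonamide nitrogen gives a 3.2-fold lower number from compound 3 to compound 4 (0.50 log units; beyond the scatter). The change removes a whole six-membered aromatic ring, yet the number falls, though the step is modest. Nothing available gives a reason for this step.

As far as these compounds go, whether a methyl or an acetyl group on the same nitrogen would stay close to compound 4 remains open. Also open, from the compounds shown here alone, is whether a phenyl ring there would match compound 3.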